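The source may hold more compounds than are shown below. What is called first, only, known or untested is meant among the compounds shown, and "the series" means these compounds.

In a functional assay on HCT-116 cells (Homo sapiens) for cytotoxicity, read by sulforhodamine B assay (a lower number here means that less compound is needed, a higher number that more compound is needed for the effect), compound 1 `CCCCCCCCCCCCCCCCCCCCCCCCc1cn([C@@H](CO)[C@H](O)[C@H](O)CCCCCCCCCCCCCC)nn1` gives > 50000 nM, which is a limit of the assay and not a number. Compound 1 thus stands on (the limit of > 50000 nM in this assay, at which 1 of the 2 values shown sits). Compound 2 `CCCCCCCCCCCCC/C=C/[C@@H](O)[C@H](CO)n1cc(CCC)nn1` gives a measured number in this assay, 16000 nM. Compounds 1 and 2 differ in more than one place, so no single step can be read from this pair.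

Compound 3 `CCCCCCCCCCCCCC[C@@H](O)[C@@H](O)[C@H](CO)n1cc(CCCCCCCCCCCCC)nn1` is related to compound 1 by one change: hydrogen in place of undecyl on a saturated chain carbon, ten or more bonds along the chain from an aromatic carbon. Hydrogen takes the place of undecyl on a saturated chain carbon.

Going by the values given here, no measured step shows what this change does, so any size given for it is only an expectation. A modest move toward a lower number in this assay is expected, resting on compound 2, which reaches a measurable 16000 nM. The expected step is an at least 1.6-fold lower number from compound 1 to compound 3 (0.22 log units; that floor lies within the scatter). A reading that again reports only a limit would be no surprise. For compound 3 the estimated value is 30000 nM, with an expected range from 12000 nM to 50000 nM.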

Compound 3, half-maximal effective concentration: > 50000 nM
Compound 3: no number, only a limit; the forecaster's own chance of this, stated with the estimate: 45%; middle value at least 1.6-fold (0.22 log units) away from the limit.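

In this assay compound 3 gives > 50000 nM, which is a limit of the assay and not a number. Compound 1 also gives only a limit, and no step can be read between compound 1 and compound 3. The compounds shown leave open whether hydrogen in place of undecyl changes this read-out at all, and in which direction.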